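A nitro group gives way to methyl

The source may report more compounds than this note shows. Statements on the series, on what has been measured and on what is new or still open speak of the compounds shown alone.

Measured in an ADME assay on Jurkat cells (Homo sapiens) for cytotoxicity, read by trypan blue exclusion, with a stated time of 24 h; a higher number here means a weaker inhibitor, a lower number a stronger inhibitor:
Compound 1 (`CN(C)c1ccc([Se]C#N)cc1`): 29300 nM
Compound 2 (`N#C[Se]Cc1ccc([N+](=O)[O-])cc1`): 6860 nM
Compound 3 (`N#C[Se]Cc1cccc([N+](=O)[O-])c1`): 12200 nM

Compound 2, at 6860 nM, stands at the low end of this small set together with compound 3, at 12200 nM, and the two lie within the scatter of each other. Compound 1, at 29300 nM, stands beyond the scatter above compound 2.

The next compound to be tested is compound 4 (`Cc1ccc(C[Se]C#N)cc1`), which has methyl in place of nitro on an aromatic carbon of compound 2: methyl in place of nitro on an aromatic carbon. Going by the values given here, no measured pair differs in one place only, so the data offer no direct guide to this change. Compound 1, which has no nitro, gives 29300 nM, so a small upward move is expected rather than a large one, of about the size of the scatter. The expected step is a 1.6-fold higher number from compound 2 to compound 4 (0.21 log units; within the scatter). Compound 4 is estimated at 11000 nM, with an expected range of 5000 nM to 25000 nM.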

Compound 4, half-maximal inhibitory concentration: 14400 nM
For compound 4 the middle estimate is 1.3-fold (0.12 log units) below the measured one; measured number inside the range.
By their numbers in this assay, from the lowest: compounds 2, 3 and 4 (each within the scatter of the next, the first and the last beyond it); then compound 1.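

Going by these compounds alone, the step of a 2.1-fold higher number from compound 2 to compound 4 (0.32 log units; beyond the scatter) in this assay is the first to compare two compounds that differ in one place only, here methyl in place of nitro on an aromatic carbon, para to a group of 4 heavy atoms. It shows that this position responds to the change, although only modestly, and that the nitro group can be replaced without a large move in the number. No measurement shown here explains why the number moves with this change.

From the compounds shown here alone, how an amine, a methoxy group or a chlorine atom at this position would compare with methyl and nitro remains open. Going by these compounds, it is also open whether the same replacement would give a similar step with the nitro group of compound 3.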